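The source may hold more compounds than are shown below. What is called first, only, known or untested is meant among the compounds shown, and "the series" means these compounds.

Three compounds share one core and differ only in the group attached to a carbonyl carbon. Compound 1 `O=C(O)c1cnn(-c2cccc(-c3cccc(C(=O)N4CCCCC4)c3F)c2)c1C1CC1` carries a piperidin-1-yl there; in an assay on BEAS-2B cells for activation of nuclear factor erythroid 2-related factor 2 (Homo sapiens), read by MTT assay, with a stated time of 48 h (on this read-out higher numbers stand for an effect only at larger amounts of compound and lower numbers for an effect already at smaller amounts), compound 1 gives 2300 nM. Compound 2 `CN(CC1CC1)C(=O)c1cccc(-c2cccc(-n3ncc(C(=O)O)c3C3CC3)c2)c1F` carries a (cyclopropylmethyl)(methyl)amino group, and in this assay compound 2 gives 2200 nM. Compound 3 `O=C(O)c1cnn(-c2cccc(-c3cccc(C(=O)N4CCCC5(CCCC5)C4)c3F)c2)c1C1CC1` carries a bigger amine group at the same carbonyl carbon, and in this assay compound 3 gives 3700 nM. Compound 3 has the highest number of the three, but all three values sit close together: a 1.6-fold higher number from compound 1 to compound 3 (0.21 log units; within the scatter), a 1.7-fold higher number from compound 2 to compound 3 (0.23 log units; within the scatter), and a 1.0-fold lower number from compound 1 to compound 2 (0.02 log units; within the scatter).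

Compound 4 `O=C(O)c1cnn(-c2cccc(-c3cccc(C(=O)N(CC4CC4)CC4CC4)c3F)c2)c1C1CC1` has not yet been measured. It differs from compound 3 by a group of 9 heavy atoms (8 carbon, 1 nitrogen; 2 three-membered non-aromatic rings of carbon only) in place of a group of 10 heavy atoms (9 carbon, 1 nitrogen; one five-membered non-aromatic ring of carbon only, one six-membered non-aromatic ring with 1 hetero atom), on a carbonyl carbon. All three measured steps swap one group on this same carbonyl carbon, and none of them moved the number beyond the scatter, so a further swap at this position is expected to leave the number where it is, with no step beyond the scatter in either direction. Compound 4 is therefore expected to give about 2600 nM in this assay, with a range from 1200 nM to 5500 nM. This amounts to an expected step of a 1.4-fold lower number from compound 3 to compound 4 (0.15 log units; within the scatter).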

Compound 4, half-maximal effective concentration in the nuclear factor erythroid 2-related factor 2 assay: 3500 nM
Estimate against measurement, compound 4: 1.3-fold (0.13 log units) below, within the range that was stated.
By their numbers in the nuclear factor erythroid 2-related factor 2 assay, from the lowest: compounds 2, 1, 4 and 3 (each within the scatter of the next).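

In the nuclear factor erythroid 2-related factor 2 assay, compound 3 gives 3700 nM and compound 4 gives 3500 nM and bis(cyclopropylmethyl)amino in place of the group with a five-membered and a six-membered ring gives a 1.1-fold lower number from compound 3 to compound 4 (0.02 log units; within the scatter), so even replacing those two rings with two three-membered rings on this carbonyl carbon produces no step beyond the scatter. In the nuclear factor erythroid 2-related factor 2 assay, the same holds for the change from piperidin-1-yl (a 1.5-fold higher number from compound 1 to compound 4 (0.18 log units; within the scatter)) and for cyclopropyl in place of hydrogen on a saturated chain carbon bound to an amide-type nitrogen (a 1.6-fold higher number from compound 2 to compound 4 (0.20 log units; within the scatter)), so none of the four groups now shown at this position separates from the others. The exchange between compound 3 and compound 4 also stays within the scatter in a physicochemical assay for lipophilicity, read by HPLC, at pH 2 (on this read-out higher numbers stand for higher lipophilicity and lower numbers for lower lipophilicity), where compound 3 gives 3.7 and compound 4 gives 3.5 (a number 0.20 log units lower from compound 3 to compound 4 (within the scatter)).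

Nothing available explains why these swaps leave the number in place. Every group shown at this carbon holds only carbon and one nitrogen, and whether morpholin-4-yl or a piperidine carrying a hydroxyl group would move the number beyond the scatter stays open.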